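A few compounds are considered here, and "the series" means these few. Any claim that something is new, unique, unknown or untested is made for them only; others in the source may bear on it.

Measured in a functional assay on NCI-H1975 cells (Homo sapiens) for inhibition, read by sulforhodamine B assay, with a stated time of 48 h; on this read-out lower numbers stand for stronger inhibition of growth and higher numbers for weaker inhibition of growth:
- compound 1 `CC(C)c1cc(C(=O)Nc2cccc(NC(=O)CCCCCCC(=O)NO)c2)c(O)cc1O`: > 10000 nM
- compound 2 `CC(C)c1cc(C(=O)N(c2ccc(NC(=O)CCCCCCC(=O)NO)cc2)C(C)C)c(O)cc1O`: > 10000 nM
- compound 3 `CC(C)c1cc(C(=O)Nc2ccccc2NC(=O)CCCCCCC(=O)NO)c(O)cc1O`: > 10000 nM

Each of these values is a limit of the assay and not a number. Compound 1 stands at such a limit, > 10000 nM, and it has no better placed neighbour: the limit of > 10000 nM in this assay, at which 3 of the 3 values shown sit.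

Compound 4 `CCN(C(=O)c1cc(C(C)C)c(O)cc1O)c1cccc(NC(=O)CCCCCCC(=O)NO)c1` differs from compound 1 by one change, (ethyl in place of hydrogen on an amide-type nitrogen), which puts ethyl in place of hydrogen on an amide-type nitrogen. Compound 2 also lacks the amide hydrogen, and its > 10000 nM is a limit too.

Going by the values given here, no measured step shows what this change does, so no step beyond the scatter is expected in either direction. The expected change is a step that the limit leaves unreadable from compound 1 to compound 4. For compound 4 the estimated value is 12000 nM, with an expected range from 3000 nM to 30000 nM.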

Compound 4, concentration for 50% growth inhibition: 940 nM
Compound 4: the middle estimate sits 13-fold (1.11 log units) above what was measured; the whole stated range lies above it.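

In this assay, ethyl in place of hydrogen on an amide-type nitrogen brings an at least 10-fold lower number from compound 1 to compound 4 (1.02 log units; beyond the scatter). Compound 1 gives > 10000 nM, which is a limit of the assay and not a number. Compound 4 is the only compound shown with a number, so on the core of compound 1 the amide hydrogen is not required for growth inhibition, and replacing it with ethyl brings a large gain.

The compounds shown leave open whether methyl or a longer chain such as propyl on this nitrogen would act like ethyl. They also leave open whether a benzyl group there would be tolerated.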